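Trifluoromethyl in Place of Hydrogen: What to Expect for Compound 4

The source may report more compounds than this note shows. Statements on the series, on what has been measured and on what is new or still open speak of the compounds shown alone.

Three compounds have been measured in a functional assay on HeLa cells (Homo sapiens) for antiproliferative activity, with a stated time of 24 h; a higher number here means a weaker inhibitor, a lower number a stronger inhibitor:

Compound 1, `NC(=O)c1c(NC(=O)c2ccccc2Cl)sc2c1CCN(Cc1ccccc1Cl)C2`, gives 27500 nM.
Compound 2, `NC(=O)c1c(NC(=O)c2ccccc2Cl)sc2c1CCN(Cc1ccc([N+](=O)[O-])cc1)C2`, gives 46100 nM.
Compound 3, `NC(=O)c1c(NC(=O)c2ccccc2Cl)sc2c1CCN(C(=S)Nc1ccccc1)C2`, gives 46700 nM.

Compound 3 has the highest of the three numbers, yet its gaps to the others are small: a 1.0-fold higher number from compound 2 to compound 3 (0.01 log units; within the scatter) and a 1.7-fold higher number from compound 1 to compound 3 (0.23 log units; within the scatter), both within the scatter, so no order among the three can be claimed.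

Compound 4, `NC(=O)c1c(NC(=O)c2ccccc2Cl)sc2c1CCN(C(=S)Nc1ccc(C(F)(F)F)cc1)C2`, differs from compound 3 in one place: trifluoromethyl in place of hydrogen on an aromatic carbon. Among the measured compounds shown here, no measured step involves a trifluoromethyl group, so nothing bears on it directly. The steps that exist, a 1.7-fold higher number from compound 1 to compound 2 (0.22 log units; within the scatter) and a 1.7-fold higher number from compound 1 to compound 3 (0.23 log units; within the scatter), changed groups on the same ring amine nitrogen and stayed within the scatter. Compound 4 is therefore expected to show no step beyond the scatter, a 1.0-fold lower number from compound 3 to compound 4 (0.02 log units; within the scatter). Compound 4 is estimated at 45000 nM, within a range from 18000 nM to 110000 nM.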

Compound 4, half-maximal inhibitory concentration: > 50000 nM
Compound 4: only a limit was reported; the forecaster's own chance of this, stated with the estimate: 20%; middle value at least 1.1-fold (0.04 log units) from the limit.
By their numbers in this assay, from the lowest: compounds 1, 2 and 3 (each within the scatter of the next). At a limit, above all of these: compound 4.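

In this assay compound 4 gave only a limit of the assay, not a number: the limit of > 50000 nM in this assay, at which 1 of the 4 values shown sits. Trifluoromethyl in place of hydrogen, para to a large group, gives an at least 1.0-fold higher number from compound 3 to compound 4 (0.02 log units; that floor lies within the scatter). This is the first change shown on this aromatic ring rather than on the ring amine nitrogen, and it brought no sign of a stronger inhibitor, though the true size of the step cannot be read. From the compounds shown here alone, whether an amine or a methoxy group at this position would give a lower number remains open.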